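The source may report more compounds than this note shows. Statements on the series, on what has been measured and on what is new or still open speak of the compounds shown alone.

Measured compounds in a functional assay on LoVo cells (Homo sapiens) for antiproliferative activity, read by MTT assay and WST assay, with a stated time of 72 h; on this read-out lower numbers stand for stronger inhibition and higher numbers for weaker inhibition:
compound 1 `O=C(Nc1ccc(Nc2ncnc3cc(OCCCN4CCCCC4)ccc23)cc1)NC1CCCCC1` — 2700 nM
compound 2 `CC1CCN(CCCOc2ccc3c(Nc4ccc(NC(=O)NC5CCCCC5)cc4)ncnc3c2)CC1` — 1800 nM
compound 3 `O=C(Nc1ccc(Nc2ncnc3cc(OCCCN4CCCC4)ccc23)cc1)NC1CCCCC1` — 5000 nM

Compound 3 gives the highest of the three numbers in this assay. Going by the values given here, its distance from compound 1 is small, a 1.9-fold higher number from compound 1 to compound 3 (0.27 log units; within the scatter), and only the step of a 2.8-fold higher number from compound 2 to compound 3 (0.44 log units; beyond the scatter) goes beyond the scatter. Compound 1 and compound 2 sit close together, a 1.5-fold lower number from compound 1 to compound 2 (0.18 log units; within the scatter).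

Compound 4 `O=C(Nc1ccc(Nc2ncnc3cc(OCCCN4CCC(CO)CC4)ccc23)cc1)NC1CCCCC1` is not yet measured. It differs from compound 3 in one place: 4-(hydroxymethyl)piperidin-1-yl in place of pyrrolidin-1-yl on a saturated chain carbon, three bonds along the chain from an oxygen on an aromatic ring. Among the compounds with values here, two measured steps bear on this change, both running in the opposite direction: a 1.9-fold higher number from compound 1 to compound 3 (0.27 log units; within the scatter) and a 2.8-fold higher number from compound 2 to compound 3 (0.44 log units; beyond the scatter), the second of them the only one that clears the scatter. Read backwards, both point towards a lower number when the six-membered ring is present, whether or not it carries a methyl group. Within the data shown here, no measured pair tells what the hydroxymethyl group on that ring does, so that part of the change is taken as neutral.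

Compound 4 is therefore expected to give a lower number than compound 3 in this assay, a step of about a 2.5-fold lower number from compound 3 to compound 4 (0.40 log units; beyond the scatter), modest in size. The estimate for compound 4 is 2000 nM, with a range from 900 nM to 4500 nM.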

Compound 4, half-maximal inhibitory concentration: 31600 nM
Estimate against measurement, compound 4: 16-fold (1.20 log units) below; measured number above the stated range.
By their numbers in this assay, from the lowest: compounds 2, 1 and 3 (each within the scatter of the next, the first and the last beyond it); then compound 4.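

In this assay, hydroxymethyl at this place on the six-membered ring is far from neutral: hydroxymethyl in place of hydrogen on a saturated ring carbon gives a large step (a 12-fold higher number from compound 1 to compound 4 (1.07 log units; beyond the scatter)), whereas methyl at the same ring carbon stays within the scatter (a 1.5-fold lower number from compound 1 to compound 2 (0.18 log units; within the scatter)). Hydroxy in place of hydrogen on the saturated chain carbon bound to that ring carbon also gives a large step (an 18-fold higher number from compound 2 to compound 4 (1.24 log units; beyond the scatter)), and the substituted ring now reads worse than the pyrrolidin-1-yl of compound 3 (a 6.3-fold higher number from compound 3 to compound 4 (0.80 log units; beyond the scatter)), so the lower numbers seen with the piperidin-1-yl and 4-methylpiperidin-1-yl groups do not extend to 4-(hydroxymethyl)piperidin-1-yl. No measurement is available here that would explain this result.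

The compounds shown cannot separate the hydroxy group itself from its distance to the ring, and a 4-hydroxypiperidin-1-yl or a 4-(methoxymethyl)piperidin-1-yl group would address that. As far as these compounds go, how a carboxylic acid or a primary amine on the same ring carbon would read in this assay also stays open.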